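This account rests on a few compounds, and the source may have more. Where it says the series, first, only, none or still open, it means among the compounds named here.

Going by the values given here, compound 2 `Cc1cncn1CCC(C(N)=O)(c1ccccc1)c1ccccc1` gives 0.86 nM in an assay on ileum with muscarinic acetylcholine receptor M3 (Cavia porcellus) as the target (on this read-out higher numbers stand for weaker inhibition and lower numbers for stronger inhibition), the lowest of the two numbers so far; compound 1 `CC(C)c1nccn1CCC(C(N)=O)(c1ccccc1)c1ccccc1` gives 1.8 nM in this assay. Among the compounds with values here, the only measured step, a 2.1-fold lower number from compound 1 to compound 2 (0.32 log units; beyond the scatter), replaces the isopropyl-bearing imidazole with the methyl-bearing one. Compound 3 `NC(=O)C(CCn1cnc2ccccc21)(c1ccccc1)c1ccccc1` changes the same position again: 1H-benzimidazol-1-yl in place of 5-methyl-1H-imidazol-1-yl on a saturated chain carbon, three bonds along the chain from two aromatic carbons and a carbonyl carbon. Within the data shown here, no measured step swaps the azole for a fused bicycle, so the sole pointer is that the group with the higher heavy-atom count at this position, in compound 1, gave 1.8 nM. A modest rise is therefore expected, a 1.9-fold higher number from compound 2 to compound 3 (0.27 log units; within the scatter). Compound 3 is estimated at 1.6 nM, expected between 0.5 nM and 5 nM.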

Compound 3, antagonist equilibrium constant: 2130 nM
Compound 3: middle estimate off by 1300-fold (3.12 log units), on the low side, outside the stated range (above it).
By their numbers in this assay, from the lowest: compound 2; then compound 1; then compound 3.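

In this assay, 1H-benzimidazol-1-yl is far less well accepted at this position than either substituted imidazole: a 2500-fold higher number from compound 2 to compound 3 (3.39 log units; beyond the scatter) and a 1200-fold higher number from compound 1 to compound 3 (3.07 log units; beyond the scatter), both much larger than a 2.1-fold lower number from compound 1 to compound 2 (0.32 log units; beyond the scatter). Relative to 5-methyl-1H-imidazol-1-yl, the entering group keeps the five-membered aromatic ring and the hydrogen-bond counts but adds one six-membered aromatic ring of carbon only. Nothing available explains the size of this loss.

The compounds shown leave open whether a phenyl substituent on the imidazole, or a piperidine in its place, would keep numbers like those of compound 1 and compound 2.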